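Adding methoxy to the nitrophenyl pyrazole amide

The compounds below may be only part of what the source reports. "The series", "measured", "known", "first", "only" and "open" are said of these compounds alone.

Compound 1 `COc1ccc(NC(=O)c2cn(-c3ccccc3)nc2-c2ccccc2)cc1`: 1350 nM
Compound 2 `O=C(Nc1ccccc1)c1cn(-c2ccccc2)nc1-c1ccc([N+](=O)[O-])cc1`: 2010 nM

Of the compounds shown here, two on a shared core have been measured in a functional assay on HCT-116 cells (Homo sapiens) for cytotoxicity, read by MTT assay, with a stated time of 48 h; a lower number here means a stronger inhibitor, a higher number a weaker inhibitor. Compound 1 carries a methoxy group on its anilide ring and a plain phenyl ring on the core; in this assay compound 1 gives 1350 nM. Compound 2 has a plain anilide and a nitrophenyl ring on the core; in this assay compound 2 gives 2010 nM. Compound 2 has the higher of the two numbers, but its gap to compound 1 lies within the scatter, so the two cannot be told apart.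

Compound 3 `COc1ccc(NC(=O)c2cn(-c3ccccc3)nc2-c2ccc([N+](=O)[O-])cc2)cc1` joins both features: it keeps the nitrophenyl ring of compound 2 and adds the change (methoxy in place of hydrogen on an aromatic carbon), sitting para to a large group. Among the compounds with values here, no measured pair shows this change alone. The nearest guide is compound 1, whose methoxy anilide gives 1350 nM, a number close to that of compound 2. The step is therefore expected to be small, if anything toward a lower number: a 1.3-fold lower number from compound 2 to compound 3 (0.13 log units; within the scatter). Compound 3 is estimated at 1500 nM, with a likely range of 600 nM to 3800 nM.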

Compound 3, half-maximal inhibitory concentration: 1020 nM
Compound 3: middle estimate off by 1.5-fold (0.17 log units), on the high side; measured number inside the range.
By their numbers in this assay, from the lowest: compounds 3, 1 and 2 (each within the scatter of the next).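

In this assay, compound 2 and compound 3 differ only by the methoxy group, which sits on an aromatic carbon para to a large group, and this single change reads as a 2.0-fold lower number from compound 2 to compound 3 (0.29 log units; within the scatter), so at this position methoxy cannot be told apart from hydrogen. Compound 1 and compound 3 likewise differ in one place, the nitro group on the ring attached to the shared core, and that change reads as a 1.3-fold lower number from compound 1 to compound 3 (0.12 log units; within the scatter), so nitro cannot be told apart from hydrogen there either, and neither change has a measurable effect on its own in these compounds. No further data are available to explain these readings.

Because both steps stay within the scatter, the compounds shown do not yet identify any group at either place that clearly separates from hydrogen. From the compounds shown here alone, whether an amine, a carboxylic acid or a longer chain such as ethoxy in place of the methoxy group would give a step beyond the scatter remains open, as does whether any such step would hold with and without the nitro group.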